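Mirror-image pair in a nitric oxide release assay

The compounds below may be only part of what the source reports. "The series", "measured", "known", "first", "only" and "open" are said of these compounds alone.

Measured so far:
Compound 1, `COC(=O)CC1=CC[C@H]2[C@H](C[C@@H]1C)OC(=O)[C@H]2C`: in a functional assay on BV-2 cells (Mus musculus, strain C57BL6/J) for inhibition, read by Griess assay, with a stated time of 24 h (on this read-out higher numbers stand for weaker inhibition and lower numbers for stronger inhibition), compound 1 gives > 10000 nM, which is a limit of the assay rather than a number.
Compound 2, `COc1cc([C@H]2Oc3c(OC)cc(C(=O)[C@@H](O)CO)cc3[C@@H]2CO)ccc1O`: in this assay compound 2 gives > 10000 nM, again a limit of the assay rather than a number.

Compound 2 therefore stands where every value shown so far stands: at the limit, with no number to compare. This is summed up by the limit of > 10000 nM in this assay, at which 2 of the 2 values shown sit. Neither compound gives a measurable inhibition within the tested range.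

Compound 3, `COc1cc([C@@H]2Oc3c(OC)cc(C(=O)[C@H](O)CO)cc3[C@H]2CO)ccc1O`, is the mirror image of compound 2. The change is this: the two compounds have the same atoms and bonds and differ only in configuration as drawn: 3 of 3 stereo elements differ (all stereocentres are inverted: mirror images); a stereocentre at a saturated ring carbon is drawn S in compound 2 and R in compound 3; a stereocentre at a saturated chain carbon is drawn S in compound 2 and R in compound 3; a stereocentre at a saturated ring carbon is drawn R in compound 2 and S in compound 3. For the measured compounds named here, no step between two measured compounds is available here, so the size of the change in this assay on going to the mirror image cannot be read from the data.

Compound 3 is expected to give 20000 nM in this assay, with a range from 5000 nM to 80000 nM. The expected step that the limit leaves unreadable from compound 2 to compound 3 is thus none beyond the scatter, since compound 2 sits at the limit > 10000 nM and there is no sign that turning every stereocentre over would bring the value into the measurable range.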

Compound 3, half-maximal inhibitory concentration: > 10000 nM
Compound 3: only a limit was reported (the forecaster's own chance of this, stated with the estimate: 80%); the middle value lies beyond the limit too.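

In this assay compound 3 gives > 10000 nM, again a limit of the assay and not a number. For the compounds shown here, compound 2 also sits at a limit, so no step from compound 2 to compound 3 can be read. On these data alone, whether these mirror images differ at all in this assay remains open.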